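This account rests on a few compounds, and the source may have more. Where it says the series, first, only, none or still open, it means among the compounds named here.

Working notes on the series. Among the measured compounds shown here, compound 1 `CCOc1ccccc1-c1ccc(-c2nc3cnccc3c(N[C@H](CC)C(N)=O)c2C#N)cc1` gives 3 in a physicochemical assay for lipophilicity, read by HPLC, at pH 7.5 (a higher number here means a more lipophilic compound, a lower number a more polar compound), the highest of the three numbers measured so far. Compound 2 `CC[C@@H](Nc1c(C#N)c(-c2ccc(-c3ccccc3OC)cc2)nc2cnccc12)C(N)=O` gives 2.7, and the step of a number 0.30 log units lower from compound 1 to compound 2 (within the scatter) lies within the scatter. Compound 3 `CC[C@@H](Nc1c(C#N)c(-c2ccc(Br)cc2)nc2cnccc12)C(N)=O` gives 2.2, with the steps of a number 0.80 log units lower from compound 1 to compound 3 (beyond the scatter) and a number 0.50 log units lower from compound 2 to compound 3 (beyond the scatter) both modest but beyond the scatter.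

Compound 4 `CCOc1ccccc1-c1ccc(-c2nc3cnccc3c(N)c2C#N)cc1` has not yet been measured in this assay. It differs from compound 1 as follows: hydrogen in place of 1-carbamoylpropyl on a nitrogen on an aromatic ring. For the measured compounds named here, none of the measured steps touches this position; all three concern the aromatic carbon at the other end of the shared core, so no measured step bears directly on the change from compound 1 to compound 4. Going by the values given here, the group that leaves carries both a chain of carbons and a carbamoyl with a donor and an acceptor, and the data give no step that separates these contributions. The expected step is therefore small and uncertain, a number 0.10 log units lower from compound 1 to compound 4 (within the scatter), without a firm direction beyond the scatter. Compound 4 is estimated at 2.9, in a range from 2.3 to 3.5.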

Compound 4, distribution coefficient: 3
For compound 4 the middle estimate is 0.10 log units below the measured one; the range from low to high includes it.
By their numbers in this assay, from the lowest: compound 3; then compounds 2, 1 and 4 (each within the scatter of the next).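

At this position, on a nitrogen on an aromatic ring, taking away the whole 1-carbamoylpropyl group to leave an amino group gives no change at the digits printed from compound 1 to compound 4 (within the scatter) in this assay. Among the compounds shown here, the earlier steps all concerned another place in the structure, so this is the first reading at this position, and here the carbamoyl, the carbon chain and the defined stereocentre can go together without a step beyond the scatter. The data shown offer no reason for this result.

Going by these compounds, the change is read only with the 2-ethoxyphenyl group in place, so it remains open whether it would hold with the 2-methoxyphenyl of compound 2 or the bromo of compound 3. Also open, on these data alone, is how a methyl, a longer chain or a carboxylic acid on this nitrogen would read, and how far the carbamoyl and the chain each contribute on their own.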